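A Furan Ring in Place of Chlorine on a Nucleoside

This account rests on a few compounds, and the source may have more. Where it says the series, first, only, none or still open, it means among the compounds named here.

Three compounds share a sugar joined to a fused nitrogen base and differ only in that base. Compound 1 `C#C[C@@]1(O)[C@@H](CO)O[C@@H](n2cnc3c(-c4ccc(OC)cc4)ncnc32)[C@@H]1O` has a base unlike the other two. In a functional assay on L1210 cells (Mus musculus) for antiproliferative activity, read by cell counting, with a stated time of 48 h (on this read-out lower numbers stand for stronger inhibition and higher numbers for weaker inhibition), compound 1 reaches only the limit of the assay, > 250000 nM, so no number is known for it. Compound 2 `C#C[C@@]1(O)[C@@H](CO)O[C@@H](n2cc(Cl)c3c(N)ncnc32)[C@@H]1O` carries chlorine on its base. In this assay, going by the values given here, compound 2 gives 14 nM, the only number in this set. The other entry, that of compound 1, is a limit (the limit of > 250000 nM in this assay, at which 1 of the 2 values shown sits). Compound 3 `C#C[C@@]1(O)[C@@H](CO)O[C@@H](n2cc(-c3ccco3)c3c(N)ncnc32)[C@@H]1O` differs from compound 2 in one place: furan-2-yl in place of chloro on an aromatic carbon. Among the compounds with values here, no measured pair here shows the effect of such a change. The step is expected to be a 5.7-fold higher number from compound 2 to compound 3 (0.76 log units; beyond the scatter) in this assay, toward weaker inhibition and a little beyond the usual scatter. Compound 3 is therefore expected to give 80 nM in this assay, within 15 nM to 600 nM.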

Compound 3, half-maximal inhibitory concentration: 30000 nM
Compound 3: middle estimate off by 380-fold (2.57 log units), on the low side, outside the stated range (above it).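

Going by these compounds alone, this is the first measured pair at this position, an aromatic carbon of the five-membered ring, and it shows that the position does not accept every group. In this assay, replacing the single chlorine atom with the five heavy atoms of furan-2-yl gives a 2100-fold higher number from compound 2 to compound 3 (3.33 log units; beyond the scatter), a large move toward weaker inhibition, although compound 3 still gives a real number rather than a limit. Nothing measured here explains why this one change costs so much.

The compounds shown cannot tell whether the loss comes with any ring at this position or with furan in particular, which a thiophene or phenyl ring could help to separate. On these data alone, it also remains open where the tolerance ends among smaller groups, such as methyl, bromine or a nitrile.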